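This account rests on a few compounds, and the source may have more. Where it says the series, first, only, none or still open, it means among the compounds named here.

Two compounds measured in a functional assay on KM12 cells (Homo sapiens) for inhibition, read by sulforhodamine B assay, with a stated time of 48 h (a higher number here means a weaker inhibitor of growth, a lower number a stronger inhibitor of growth), frame this step. Compound 1 `COc1cc(C)cc(-c2c(-c3ccnc(-c4ccc(C(C)=O)cc4)c3)cnn2CC#N)c1` gives 2870 nM in this assay, the higher of the two numbers seen so far. Compound 2 `Cc1cc(O)cc(-c2nn(CC#N)cc2-c2ccnc(-c3ccc(Oc4ccccc4)cc3)c2)c1` gives 1920 nM in this assay; the gap between these two values lies within the scatter, so the two compounds cannot be told apart on these numbers. Compound 3 `COc1cc(C)cc(-c2c(-c3ccnc(-c4ccc(N(C)C)cc4)c3)cnn2CC#N)c1` has not yet been measured. It differs from compound 1 in one place: dimethylamino in place of acetyl on an aromatic carbon. For the measured compounds named here, no measured pair shows what a change of this kind does here, so the expectation rests only on the two values known. The estimated step from compound 1 to compound 3 is a 1.4-fold lower number from compound 1 to compound 3 (0.16 log units; within the scatter), a small gain that may well turn out to lie within the scatter. Compound 3 is expected to give about 2000 nM in this assay, with a likely range from 700 nM to 6000 nM.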

Compound 3, concentration for 50% growth inhibition: 47.5 nM
Estimate against measurement, compound 3: 42-fold (1.62 log units) above, and the stated range ends above it.
By their numbers in this assay, from the lowest: compound 3; then compounds 2 and 1 (each within the scatter of the next).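

In this assay, putting dimethylamino in place of acetyl on the phenyl ring gives a 60-fold lower number from compound 1 to compound 3 (1.78 log units; beyond the scatter), so the group at this position can strongly change growth inhibition on these cells. This large step comes with no change in the counts of heavy atoms or hydrogen-bond acceptors and no net charge on either group, so those counts do not account for the gap between the two compounds. Nothing in the available data explains why these two groups behave so differently.

A single pair cannot show whether the gain is specific to dimethylamino or would also appear with another amine at this position, such as pyrrolidine or morpholine. On these data alone, it also remains open whether the same change would have a similar effect when other parts of the molecule differ.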